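A few compounds are considered here, and "the series" means these few. Any claim that something is new, unique, unknown or untested is made for them only; others in the source may bear on it.

Working notes on the series. Compound 1 `FC(F)(F)c1cnc(N2CCC(NC(=S)Nc3cnc4ccccc4c3)CC2)c(Cl)c1` and compound 2 `COc1ccc(NC(=S)NC2CCN(c3ncc(C(F)(F)F)cc3Cl)CC2)cn1` share a common core and differ only in the aryl group on an amide-type nitrogen. In an assay on membranes from brain for binding affinity to Lysophosphatidylserine lipase ABHD12 (Mus musculus), read by fluorescence, with a stated time of 20 min, tested at 10 uM (on this read-out higher numbers stand for a stronger effect at the one concentration tested and lower numbers for a weaker effect), compound 1 gives 2%, and compound 2 gives 1%. The step of a number 1 percentage points lower from compound 1 to compound 2 (within the scatter), 6-methoxypyridin-3-yl in place of quinolin-3-yl, left the read-out unmoved, so compound 2 and compound 1 stand together at a weak read-out, with numbers within the scatter of each other. Compound 3 `FC(F)(F)c1cnc(N2CCC(NC(=S)Nc3ccccc3)CC2)c(Cl)c1` carries the change (phenyl in place of 6-methoxypyridin-3-yl on an amide-type nitrogen). Among the compounds with values here, the single measured step, from compound 1 to compound 2, varied the same aryl group and stayed within the scatter; neither aryl group lifted the read-out. The expectation is therefore a step of a number 1 percentage points higher from compound 2 to compound 3 (within the scatter) that stays within the scatter. Compound 3 is estimated at 2%, in a range from 0% to 12%.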

Compound 3, a percentage reported as inhibition, at one concentration (the size of the read-out at that concentration, not a potency): 96%
Compound 3: the middle estimate sits 94 percentage points below what was measured; measured number outside the range, above it.
By their numbers in this assay, from the lowest: compounds 2 and 1 (each within the scatter of the next); then compound 3.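

Phenyl in place of 6-methoxypyridin-3-yl gives a number 95 percentage points higher from compound 2 to compound 3 (beyond the scatter) in this assay, and phenyl in place of quinolin-3-yl gives a number 94 percentage points higher from compound 1 to compound 3 (beyond the scatter). The group on this amide-type nitrogen can therefore decide the read-out on the shared core, which the earlier pair, with its step of a number 1 percentage points lower from compound 1 to compound 2 (within the scatter), gave no sign of; among these three compounds, only the aryl ring of carbon only stands apart. Nothing at hand bears on why the phenyl compound stands apart.

The compounds shown leave open whether the ring nitrogen, the methoxy group or the larger fused ring separates compound 1 and compound 2 from compound 3. A plain pyridin-3-yl, or a phenyl carrying a methoxy group, a fluorine or an amine, would help separate these possibilities.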